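Thiourea series: bromo to chloro exchange at compound 1

The compounds below may be only part of what the source reports. "The series", "measured", "known", "first", "only" and "open" are said of these compounds alone.

Measured so far in a functional assay on HepG2 cells (Homo sapiens) for antiproliferative activity, read by MTT assay; on this read-out higher numbers stand for weaker inhibition and lower numbers for stronger inhibition:
compound 1 `CNC(=O)c1ccc(Oc2cccc(NC(=S)Nc3ccc(Br)c(C(F)(F)F)c3)c2)nc1`: 8530 nM
compound 2 `CNC(=O)c1ccc(Oc2cccc(NC(=S)Nc3ccc(F)cc3)c2)nc1`: 42500 nM
compound 3 `CNC(=O)c1ccc(Oc2cccc(NC(=S)Nc3ccc(OC(F)(F)F)cc3)c2)nc1`: a limit of the assay, > 100000 nM

Compound 1 gives the lowest of the two numbers in this assay; compound 2 gives a higher number, and the gap between them is beyond the scatter. Compound 3 sits at the limit of the assay, which is also recorded as the limit of > 100000 nM in this assay, at which 1 of the 3 values shown sits. Among the measured compounds shown here, the one measured step, an at least 2.3-fold higher number from compound 2 to compound 3 (0.37 log units; beyond the scatter), concerns the group para on the terminal phenyl ring and says nothing about the halogen that sits ortho to the trifluoromethyl group.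

Compound 4 `CNC(=O)c1ccc(Oc2cccc(NC(=S)Nc3ccc(Cl)c(C(F)(F)F)c3)c2)nc1` differs from compound 1 by chloro in place of bromo on an aromatic carbon. For the measured compounds named here, no measured step touches this kind of exchange, so the expectation rests on the smallness of the change in this assay: one halogen for another at the same carbon, with no change in hydrogen-bond donors or acceptors. The expected step from compound 1 to compound 4 is therefore a 1.2-fold higher number from compound 1 to compound 4 (0.07 log units; within the scatter), which is within the scatter, with no clear direction.

Compound 4 is expected to give about 10000 nM in this assay, with a likely range from 4000 nM to 25000 nM.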

Compound 4, half-maximal inhibitory concentration: 5350 nM
Beside the measured number, compound 4's estimate is 1.9-fold (0.27 log units) above it; low and high end bracket the measured number.
By their numbers in this assay, from the lowest: compounds 4 and 1 (each within the scatter of the next); then compound 2. At a limit, above all of these: compound 3.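

In this assay, the exchange at this carbon, ortho to a trifluoromethyl group, gives a 1.6-fold lower number from compound 1 to compound 4 (0.20 log units; within the scatter), so chloro and bromo cannot be told apart at this position on this read-out. Among the compounds shown here, this is the first reading of a halogen exchange at this carbon with the trifluoromethyl group held in place; the only earlier step, an at least 2.3-fold higher number from compound 2 to compound 3 (0.37 log units; beyond the scatter), replaced fluoro with trifluoromethoxy in a set of compounds lacking that trifluoromethyl group and could not speak to this exchange. Nothing shown here offers a reason for the two halogens reading alike.

On these data alone, what remains open is whether this carbon accepts only a halogen or also a quite different substituent, such as an amine, a carboxylic acid or a methoxy group, with the trifluoromethyl group kept in place. Also open, as far as these compounds go, is how much of the reading depends on the trifluoromethyl group itself, which a compound carrying chloro at the same carbon and a plain hydrogen in place of trifluoromethyl would address.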